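Notes on compound 4: chloro added to compound 3

The source may hold more compounds than are shown below. What is called first, only, known or untested is meant among the compounds shown, and "the series" means these compounds.

Measured so far:
Compound 1, `COc1ccc(C2=C(c3cc(OC)c(OC)c(OC)c3)C(=O)CC2C)cc1C(=O)O`. In an ADME assay on PA-1 cells (Homo sapiens) for cytotoxicity, read by MTT assay, with a stated time of 72 h (on this read-out lower numbers stand for stronger inhibition and higher numbers for weaker inhibition), compound 1 gives > 100 ug/mL, which is a limit of the assay and not a number.
Compound 2, `COc1ccc(C2=C(c3cc(OC)c(OC)c(OC)c3)C(=O)C(OC(C)=O)C2)cc1`. In this assay compound 2 gives < 1 ug/mL, also a limit.
Compound 3, `COc1ccc(C2=C(c3cc(OC)c(OC)c(OC)c3)C(=O)C(O)C2)cc1`. In this assay compound 3 gives < 1 ug/mL, again a limit.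

Compound 3 thus stands at the limit of < 1 ug/mL in this assay, at which 2 of the 3 values shown sit, with no number of its own. Compound 1 stands at the limit of > 100 ug/mL in this assay, at which 1 of the 3 values shown sits. For the measured compounds named here, the one measured step, a step that the two limits leave unreadable from compound 2 to compound 3, is hydrogen in place of acetyl on an oxygen on a saturated carbon; both ends sit at the same limit, so its size cannot be read.

Compound 4, `COc1ccc(C2=C(c3cc(OC)c(OC)c(OC)c3)C(=O)C(O)C2)cc1Cl`, differs from compound 3 by chloro in place of hydrogen on an aromatic carbon. The chloro enters on an aromatic carbon of a six-membered aromatic ring of carbon only, ortho to a methoxy group and meta to a large group, turning 4-methoxyphenyl into 3-chloro-4-methoxyphenyl. No measured step bears on this place, and the only step shown is unreadable. The expectation for this assay therefore rests on compound 3 alone, which sits at the limit of < 1 ug/mL in this assay, at which 2 of the 3 values shown sit. Compound 4 is expected to stay near that limit, so the expected step that the limit leaves unreadable from compound 3 to compound 4 is none beyond the scatter. The estimate for compound 4 is 0.5 ug/mL, with a range from 0.1 ug/mL to 3 ug/mL; a reading that is again only a limit is likely.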

Compound 4, half-maximal inhibitory concentration: > 100 ug/mL
Compound 4 ended at the assay's limit; the forecaster's own chance of this, stated with the estimate: 60%; middle value at least 200-fold (2.30 log units) away from the limit.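

In this assay, for the compounds shown here, the change from 4-methoxyphenyl to 3-chloro-4-methoxyphenyl gives an at least 100-fold higher number from compound 3 to compound 4 (2.00 log units; beyond the scatter), so one added chlorine atom on an aromatic carbon, ortho to a methoxy group, is enough to separate two compounds that otherwise share the same core; this is the first change whose size can be read, since the earlier step on the oxygen on a saturated carbon cannot be read. Compound 3 stands at a limit of the assay and not at a number: the limit of < 1 ug/mL in this assay, at which 2 of the 4 values shown sit. Compound 4 stands at the opposite limit, which is likewise not a number: the limit of > 100 ug/mL in this assay, at which 2 of the 4 values shown sit.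

Going by these compounds, with both ends at limits, the true size of the step stays open, and so does whether the effect belongs to chloro itself or would appear with any group at this place. On these data alone, whether fluoro, a methyl group or an amine on the same aromatic carbon would stay with compound 3 or go with compound 4 is also open, as is whether chloro elsewhere on the ring would give the same result.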